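Phenyl to thiophen-2-yl on a sulfonyl sulfur

A few compounds are considered here, and "the series" means these few. Any claim that something is new, unique, unknown or untested is made for them only; others in the source may bear on it.

Compound 1 `Cc1ccc(S(=O)(=O)Nc2cc(SCC(=O)N[C@@H](CC(C)C)B(O)O)c(O)c3ccccc23)cc1`: 14000 nM
Compound 2 `CC(=O)Nc1ccc(S(=O)(=O)Nc2cc(SCC(=O)N[C@@H](CC(C)C)B(O)O)c(O)c3ccccc23)cc1`: 4450 nM
Compound 3 `CC(C)C[C@H](NC(=O)CCSc1cc(NS(=O)(=O)c2ccccc2)c2ccccc2c1O)B(O)O`: 4200 nM

All three were tested in a functional assay on MDA-MB-231 cells (Homo sapiens) for antiproliferative activity, read by sulforhodamine B assay, with a stated time of 72 h; on this read-out lower numbers stand for stronger inhibition and higher numbers for weaker inhibition. Compound 3 lies within the scatter of compound 2, while compound 1 has a higher number than either, beyond the scatter. Compound 4 `CC(C)C[C@H](NC(=O)CCSc1cc(NS(=O)(=O)c2cccs2)c2ccccc2c1O)B(O)O` alters one group of compound 3: thiophen-2-yl in place of phenyl on a sulfonyl sulfur. For the measured compounds named here, no measured step makes this swap. The nearest evidence is a 3.1-fold lower number from compound 1 to compound 2 (0.50 log units; beyond the scatter), a modest shift that comes from acetamido in place of methyl on an aromatic carbon, a different change at a different place. A step beyond the scatter is therefore not expected in this assay. The expected change is a 1.1-fold lower number from compound 3 to compound 4 (0.02 log units; within the scatter). Compound 4 is estimated at 4000 nM, with an expected range of 1800 nM to 9000 nM.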

Compound 4, half-maximal inhibitory concentration: 4450 nM
For compound 4 the middle estimate is 1.1-fold (0.05 log units) below the measured one; measured number inside the range.
By their numbers in this assay, from the lowest: compounds 3, 2 and 4 (each within the scatter of the next); then compound 1.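

On a sulfonyl sulfur, a thiophen-2-yl ring can take the place of a phenyl ring: in this assay the swap gives a 1.1-fold higher number from compound 3 to compound 4 (0.03 log units; within the scatter), so the smaller ring, with its one sulfur, leaves the number within the usual scatter. The earlier compounds shown here offered no direct step at this place. No measurement shown here explains this result.

Going by these compounds, it remains open how a furan-2-yl ring or a cyclohexyl group would fare on the same sulfur. On these data alone, whether an amine or a carboxylic acid on the thiophen-2-yl ring would move the number is also open.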